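Ring nitrogen substituent and permeability: compound 3 to compound 4

A few compounds are considered here, and "the series" means these few. Any claim that something is new, unique, unknown or untested is made for them only; others in the source may bear on it.

Measured so far in an ADME assay for permeability, using PAMPA; a higher number here means that the compound crosses the layer faster, a lower number that the compound crosses the layer more slowly:
compound 1 `CCCC[C@H](NC(=O)[C@H](CCCCN)NC(=O)[C@H](CCCNC(=N)N)NC(=O)c1ccc(/C=C2\SC(=S)N(c3ccc(Cl)cc3)C2=O)cc1)C(N)=O`: 1.02 10^-6 cm/s
compound 2 `CCCC[C@H](NC(=O)[C@H](CCCCN)NC(=O)[C@H](CCCNC(=N)N)NC(=O)c1ccc(/C=C2\SC(=S)N(C3CCCC3)C2=O)cc1)C(N)=O`: 2.31 10^-6 cm/s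
compound 3 `C=CCN1C(=O)/C(=C/c2ccc(C(=O)N[C@@H](CCCNC(=N)N)C(=O)N[C@@H](CCCCN)C(=O)N[C@@H](CCCC)C(N)=O)cc2)SC1=S`: 0.42 10^-6 cm/s

Compound 3 stands lowest of the three numbers in this assay. Its nearest neighbour is compound 1, reached by the step of a 2.4-fold lower number from compound 1 to compound 3 (0.39 log units; beyond the scatter); its furthest is compound 2, reached by the step of a 5.5-fold lower number from compound 2 to compound 3 (0.74 log units; beyond the scatter). Both steps lie beyond the scatter, so the allyl group on the ring nitrogen goes with the lowest number in this set, the cyclopentyl group with the highest, and the 4-chlorophenyl group sits in between, as the step of a 2.3-fold higher number from compound 1 to compound 2 (0.36 log units; beyond the scatter) also shows.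

Compound 4 `CCCC[C@H](NC(=O)[C@H](CCCCN)NC(=O)[C@H](CCCNC(=N)N)NC(=O)c1ccc(/C=C2\SC(=S)N(C3CCCCC3)C2=O)cc1)C(N)=O` is not yet measured in this assay. The change from compound 3 is cyclohexyl in place of allyl on an amide-type nitrogen in a ring. The step that bears most directly on it is a 5.5-fold lower number from compound 2 to compound 3 (0.74 log units; beyond the scatter), read in reverse: a saturated carbocycle in place of allyl on the same nitrogen. Within the data shown here, no measured step relates cyclohexyl to cyclopentyl; compound 2 with cyclopentyl gives 2.31 10^-6 cm/s, and the cyclohexyl analogue is expected to land near it. For compound 4 a step of a 6.0-fold higher number from compound 3 to compound 4 (0.77 log units; beyond the scatter) upward is therefore expected. Compound 4 is estimated at 2.5 10^-6 cm/s, with a range from 1.2 10^-6 cm/s to 5 10^-6 cm/s.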

Compound 4, apparent permeability: 1.82 10^-6 cm/s
For compound 4 the middle estimate is 1.4-fold (0.14 log units) above the measured one, within the range that was stated.
By their numbers in this assay, from the lowest: compound 3; then compounds 1, 4 and 2 (each within the scatter of the next, the first and the last beyond it).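

In this assay, cyclohexyl on the ring nitrogen stands well clear of allyl, with a 4.3-fold higher number from compound 3 to compound 4 (0.64 log units; beyond the scatter), so the gap first seen with cyclopentyl is now seen with a second saturated carbocycle. Changing the ring itself matters little at this position: a 1.3-fold lower number from compound 2 to compound 4 (0.10 log units; within the scatter) lies within the scatter, and cyclopentyl and cyclohexyl cannot be told apart here. With a 1.8-fold higher number from compound 1 to compound 4 (0.25 log units; within the scatter) also within the scatter, the separation between 4-chlorophenyl and cyclopentyl does not carry over to cyclohexyl, and compound 3 is now the only one of the four whose steps to all the others lie beyond the scatter.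

Allyl and cyclohexyl differ at once in size, in the ring and in the double bond outside aromatic rings, so a plain propyl group would be needed to tell whether the low number of compound 3 follows the double bond or the small open chain. Going by these compounds, it also remains open whether a substituent on this nitrogen carrying an amine or a carboxylic acid, or a longer alkyl chain, would fall with the carbocycles or with allyl.

No measured evidence on the origin of these steps is at hand.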